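Swapping Trifluoromethyl for Methoxy on Compound 1

The compounds below may be only part of what the source reports. "The series", "measured", "known", "first", "only" and "open" are said of these compounds alone.

Compound 1 `Cc1cc(-c2sc(Cc3cccc(C(F)(F)F)c3)nc2C)ccc1C(N)=O` gives 73 nM in a functional assay on cells for agonist activity at G-protein coupled receptor 52 (Homo sapiens), read by AlphaScreen and cAMP accumulation, with a stated time of 30 min (a lower number here means that less compound is needed, a higher number that more compound is needed for the effect), the lowest of the three numbers recorded so far. Compound 2 `CCc1cc(-c2sc(Cc3cccc(C(F)(F)F)c3)nc2C)ccc1C(N)=O` carries an ethyl where compound 1 carries a methyl; in this assay compound 2 gives 83 nM; the change is a 1.1-fold higher number from compound 1 to compound 2 (0.06 log units; within the scatter). Compound 3 `Cc1nc(Cc2cccc(C(F)(F)F)c2)sc1-c1ccc(C(N)=O)c(C(C)C)c1`, with an isopropyl in place of that methyl, gives 370 nM, and the step is a 5.1-fold higher number from compound 1 to compound 3 (0.70 log units; beyond the scatter), while a 4.5-fold higher number from compound 2 to compound 3 (0.65 log units; beyond the scatter). Compound 4 `COc1cccc(Cc2nc(C)c(-c3ccc(C(N)=O)c(C)c3)s2)c1` differs from compound 1 elsewhere: methoxy in place of trifluoromethyl on an aromatic carbon. Among the measured compounds shown here, none of the measured steps touches that ring; together they show only that on the other six-membered aromatic ring of carbon a methyl and an ethyl give numbers within the scatter of each other, whereas an isopropyl gives a modestly higher one. For the methoxy the data offer no comparison at all, so the expectation is correspondingly uncertain and its range is wide. Relative to compound 1, compound 4 is expected to need more, a 3.4-fold higher number from compound 1 to compound 4 (0.53 log units; beyond the scatter), and its estimated value is 250 nM, with a range from 70 nM to 900 nM.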

Compound 4, half-maximal effective concentration: 160 nM
The estimate for compound 4 lay 1.6-fold (0.19 log units) above the measured number; measured number inside the range.
By their numbers in this assay, from the lowest: compounds 1, 2 and 4 (each within the scatter of the next, the first and the last beyond it); then compound 3.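

Among the compounds shown here, this is the first measurement at the six-membered aromatic ring carrying the trifluoromethyl, and it shows that the group at this position affects the number in this assay: methoxy in place of trifluoromethyl gives a 2.2-fold higher number from compound 1 to compound 4 (0.34 log units; beyond the scatter), a modest change. It also shows that trifluoromethyl is not needed for a measurable response, since compound 4, with methoxy on the same aromatic carbon, still gives a number in this assay, although compound 1 needs less. Nothing measured here bears on the reason for this step, which therefore stands as an observation alone.

With a single replacement at this carbon, a single step cannot show how other groups would compare, such as a chlorine, a nitrile, an amine or a carboxylic acid, or a longer chain such as ethoxy. Also open, on these data alone, is whether the step would keep its size with the ethyl or the isopropyl on the other six-membered aromatic ring in place of the methyl, and whether methoxy would behave the same on another carbon of its ring.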